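From Hydroxymethyl to Carboxymethyl on the Shared Core

The compounds below may be only part of what the source reports. "The series", "measured", "known", "first", "only" and "open" are said of these compounds alone.

Three measured compounds share one core and differ in the group on the aromatic nitrogen. In a functional assay on HT-29 cells (Homo sapiens) for inhibition, with a stated time of 72 h (a lower number here means a stronger inhibitor, a higher number a weaker inhibitor), compound 1 (`CCn1ccc2cc(C(=O)c3cc(OC)c(OC)c(OC)c3)ccc21`) gives 32 nM and compound 3 (`COc1cc(C(=O)c2ccc3c(ccn3CO)c2)cc(OC)c1OC`) gives 34 nM, two values within the scatter of each other. Compound 2 (`COc1cc(C(=O)c2ccc3c(ccn3C(C)C)c2)cc(OC)c1OC`) gives 1200 nM, so compound 3 stands well clear of it on the stronger side.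

Compound 4 (`COc1cc(C(=O)c2ccc3c(ccn3CC(=O)O)c2)cc(OC)c1OC`), not yet measured, differs from compound 3 as follows: carboxy in place of hydroxy on a saturated chain carbon bound to an aromatic nitrogen. In words, carboxy takes the place of hydroxy on a saturated chain carbon bound to an aromatic nitrogen, turning hydroxymethyl into carboxymethyl.

Among the compounds with values here, three measured steps touch this same spot. Exchanging methyl for hydroxy changed nothing beyond the scatter, a 1.1-fold higher number from compound 1 to compound 3 (0.03 log units; within the scatter). Adding a methyl had a large effect, a 38-fold higher number from compound 1 to compound 2 (1.57 log units; beyond the scatter), and hydroxymethyl in place of isopropyl gave a similarly large gap, a 35-fold lower number from compound 2 to compound 3 (1.55 log units; beyond the scatter). None of these steps involves a carboxy group, so they guide only loosely. Within the data shown here, the new group also adds atoms at that carbon, and the one measured step that added atoms there, a 38-fold higher number from compound 1 to compound 2 (1.57 log units; beyond the scatter), went toward weaker inhibition.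

The expected result is a 12-fold higher number from compound 3 to compound 4 (1.07 log units; beyond the scatter), a move toward weaker inhibition. For compound 4 the estimated value is 400 nM, with an expected range from 60 nM to 3000 nM.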

Compound 4, half-maximal inhibitory concentration: 460 nM
Beside the measured number, compound 4's estimate is 1.2-fold (0.06 log units) below it, within the range that was stated.
By their numbers in this assay, from the lowest: compounds 1 and 3 (each within the scatter of the next); then compound 4; then compound 2.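

In this assay, the earlier swap of methyl for hydroxy made it look as if this saturated chain carbon accepted a change freely, but carboxy does not fit that picture: carboxy in place of hydroxy gives a 14-fold higher number from compound 3 to compound 4 (1.13 log units; beyond the scatter), and carboxy in place of methyl gives a similar a 14-fold higher number from compound 1 to compound 4 (1.16 log units; beyond the scatter). Hydroxy and carboxy carry the same counts of hydrogen-bond donors and acceptors, so those counts do not separate compound 3 from compound 4, and carboxymethyl in place of isopropyl on the aromatic nitrogen gives a 2.6-fold lower number from compound 2 to compound 4 (0.42 log units; beyond the scatter), which shows that the two groups that cost the most here do not cost the same. Nothing in the data explains any of these gaps.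

As far as these compounds go, what remains open is whether the loss follows the carboxy group itself or would also appear with a close relative such as its methyl ester or primary amide. An amine at the same carbon, or a longer chain carrying the carboxylic acid, would test how far this trend extends.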